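The source may hold more compounds than are shown below. What is called first, only, known or untested is meant among the compounds shown, and "the series" means these compounds.

Measured in a functional assay on HEK293 cells for agonist activity at 5-hydroxytryptamine receptor 4 (Homo sapiens), read by cAMP accumulation; on this read-out higher numbers stand for an effect only at larger amounts of compound and lower numbers for an effect already at smaller amounts:
- compound 1 `CC(C)n1c(=O)n(C(=O)NCCN2CCNCC2)c2ccccc21`: 7.94 nM
- compound 2 `COc1cc(N)c(Cl)cc1C(=O)NC1CCN(CCCCCO)CC1`: 15.9 nM
- compound 3 `COc1cc(N)c(Cl)cc1C(=O)NC1CCN(CCN2C(=O)c3ccccc3C2=O)CC1`: 631 nM

On these numbers compound 2 stands second highest of three. Compound 1 gives a number within the scatter of compound 2, so no order can be read between the two. Compound 3 gives a clearly higher number than compound 2, beyond the scatter.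

Compound 4 `COc1cc(N)c(Cl)cc1C(=O)NC1CCN(CCCCCN2CCN(S(C)(=O)=O)CC2)CC1` differs from compound 2 by 4-(methylsulfonyl)piperazin-1-yl in place of hydroxy on a saturated chain carbon, five bonds along the chain from an amine nitrogen in a ring. Among the measured compounds shown here, no measured pair carries this change, so no step can be computed for it. The chain end of compound 2 is extended by a ring with no hydrogen-bond donor; the step from compound 2 to compound 4 is expected to be small in this assay, a 1.3-fold higher number from compound 2 to compound 4 (0.10 log units; within the scatter), with no direction beyond the scatter. For compound 4 the estimate is 20 nM, with a range from 5 nM to 80 nM.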

Compound 4, half-maximal effective concentration: 12.6 nM
Beside the measured number, compound 4's estimate is 1.6-fold (0.20 log units) above it; low and high end bracket the measured number.
By their numbers in this assay, from the lowest: compounds 1, 4 and 2 (each within the scatter of the next); then compound 3.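

In this assay, the end of the saturated chain accepts a much larger group than compound 2 showed: 4-(methylsulfonyl)piperazin-1-yl in place of hydroxy gives a 1.3-fold lower number from compound 2 to compound 4 (0.10 log units; within the scatter). The added six-membered ring and the lost hydrogen-bond donor therefore leave no change that can be read in this series. No supporting data are available to explain this result.

Open, on these data alone, is whether a carboxylic acid or a primary amine at the chain end would hold the number within this range. Also open, as far as these compounds go, are piperazin-1-yl without methylsulfonyl and a longer chain carrying the same ring.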